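This account rests on a few compounds, and the source may have more. Where it says the series, first, only, none or still open, it means among the compounds named here.

Compound 1, `O=c1cc(Cc2c(F)cccc2F)nc(SC2CCCC2)[nH]1`, sits in a functional assay on MT4 cells (Homo sapiens) for cytotoxicity (a higher number here means that more compound is tolerated, a lower number that less compound is tolerated), at > 200000 nM, which is a limit of the assay rather than a number. Compound 2, `CC(c1cc(=O)[nH]c(SC2CCCC2)n1)c1c(F)cccc1F`, also sits at a limit in this assay, > 200000 nM. The two differ by methyl in place of hydrogen on a saturated chain carbon bound to two aromatic carbons, and the step that the two limits leave unreadable from compound 1 to compound 2 cannot be sized because both values are limits. Within the data shown here, compound 3, `Cc1c(O)nc(SC(C)C)nc1C(C)c1c(F)cccc1F`, is the only compound that gives a number in this assay, 200000 nM; the difference between its core and the core of compound 1 is not broken down here. Compound 4, `CCC(C)Sc1nc(O)c(C)c(C(C)c2c(F)cccc2F)n1`, differs from compound 3 by methyl in place of hydrogen on a saturated chain carbon, two bonds along the chain from a sulfur. This is the same kind of change as between compound 1 and compound 2, but at another place: there the carbon is bound to two aromatic carbons, here it is two bonds along the chain from a sulfur. Since compound 3 gives 200000 nM and two compounds sit at the limit of > 200000 nM in this assay, at which 2 of the 3 values shown sit, the expected step is no change at the digits printed from compound 3 to compound 4 (within the scatter), essentially flat. Compound 4 is therefore estimated at 200000 nM, between 100000 nM and 300000 nM.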

Compound 4, half-maximal cytotoxic concentration: > 200000 nM
Compound 4 gave a limit, no number; the forecaster's own chance of this, stated with the estimate: 60%; the middle value lies on the limit itself.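

In this assay, methyl in place of hydrogen on a saturated chain carbon, two bonds along the chain from a sulfur, gives a number no lower from compound 3 to compound 4 (the limit leaves the size open). The same kind of change on the carbon bound to two aromatic carbons cannot be read either, so the two steps cannot be set side by side, and the data show only that the new place brings no lower number. How far the change carries from one core to another stays unsized, because the values gather at one end of the assay: the limit of > 200000 nM in this assay, at which 3 of the 4 values shown sit.

The compounds shown leave open whether any change would bring a clearly lower number in this assay. On these data alone, how an amine or a carboxylic acid in place of the sec-butyl would read remains open.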